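This account rests on a few compounds, and the source may have more. Where it says the series, first, only, none or still open, it means among the compounds named here.

Compound 1 `Cc1ccnc2nc(-c3cccc(Cl)c3)cc(O)c12`: 52.5 nM
Compound 2 `Cc1ccc2c(O)cc(-c3cccc(Cl)c3)nc2n1`: 64.6 nM

In a functional assay on U-251 cells (Homo sapiens) for antiproliferative activity (a higher number here means a weaker inhibitor of growth, a lower number a stronger inhibitor of growth), compound 2 gives 64.6 nM, which lies within the scatter of compound 1 at 52.5 nM. Compound 3 `Cc1cccc(-c2cc(O)c3ccc(C)nc3n2)c1` has methyl in place of chloro on an aromatic carbon of compound 2: methyl in place of chloro on an aromatic carbon. Among the measured compounds shown here, no measured pair shows this swap, so there is little to go on, and no step beyond the scatter is expected in this assay. The estimated change is small: a 1.2-fold higher number from compound 2 to compound 3 (0.09 log units; within the scatter). For compound 3 the expected value is 80 nM, with an estimated range of 30 nM to 220 nM.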

Compound 3, concentration for 50% growth inhibition: 200 nM
Compound 3: middle estimate off by 2.5-fold (0.40 log units), on the low side; low and high end bracket the measured number.
By their numbers in this assay, from the lowest: compounds 1 and 2 (each within the scatter of the next); then compound 3.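

In this assay the swap of chloro for methyl gives a 3.1-fold higher number from compound 2 to compound 3 (0.49 log units; beyond the scatter) and so is not neutral on this aromatic carbon, meta to a large group. The position therefore responds to which group it carries, even though both groups have one heavy atom and neither adds a hydrogen-bond donor or acceptor. No measurement on these compounds accounts for the step.

Open, from the compounds shown here alone, is how fluoro, methoxy or an amine would fare at this place. Also open, going by these compounds, is whether the same swap gives a similar step on the core of compound 1.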